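The source may hold more compounds than are shown below. What is called first, only, known or untested is meant among the compounds shown, and "the series" means these compounds.

Measured in a functional assay on HeLa cells (Homo sapiens) for inhibition; a higher number here means a weaker inhibitor, a lower number a stronger inhibitor:

- Compound 1 `CN(C(=O)CC(CC(=O)NCCN1CCCC1)c1ccc(Cl)cc1)C1Cc2ccccc2C1`: 55400 nM
- Compound 2 `CCN(CC)CCNC(=O)CC(CC(=O)N(C)C1Cc2ccccc2C1)c1ccccc1`: > 100000 nM
- Compound 3 `CCN(CC)CCNC(=O)CC(CC(=O)N(CC)C1Cc2ccccc2C1)c1ccc(Cl)cc1`: 24300 nM

Compound 3 has the lowest number of the two true readings, which makes it the stronger inhibitor of that pair. Compound 1 gives 55400 nM, and this gap from compound 3 lies beyond the usual scatter of repeat measurements. Compound 2 gives only a limit of the assay, > 100000 nM, not an exact number.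

The next compound to consider is compound 4 `CCN(CC)CCNC(=O)CC(CC(=O)N(C)C1Cc2ccccc2C1)c1ccc(Cl)cc1`. It differs from compound 3 in one place: hydrogen in place of methyl on a saturated chain carbon bound to an amide-type nitrogen. This puts hydrogen in place of methyl on a saturated chain carbon bound to an amide-type nitrogen, so an ethyl becomes a methyl.

Among the compounds with values here, no measured pair shows this change on its own, so its size in this assay can only be judged roughly. The change is small, and a small step is expected, leaning toward a higher number. Within the data shown here, that lean rests on compound 3 holding the lowest number so far, at 24300 nM, so that there is little evidence for going lower. The expected change is a 1.4-fold higher number from compound 3 to compound 4 (0.16 log units; within the scatter). For compound 4 the estimate is 35000 nM, with an expected range from 15000 nM to 80000 nM.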

Compound 4, half-maximal inhibitory concentration: 48100 nM
For compound 4 the middle estimate is 1.4-fold (0.14 log units) below the measured one; the range from low to high includes it.
By their numbers in this assay, from the lowest: compounds 3, 4 and 1 (each within the scatter of the next, the first and the last beyond it). At a limit, above all of these: compound 2.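

In this assay, within the data shown here, the step for ethyl becoming methyl, a 2.0-fold higher number from compound 3 to compound 4 (0.30 log units; within the scatter), gives the first direct reading of this change, and it cannot be told apart from repeat-measurement noise. Among these compounds, compound 4 also gives one-place readings for two other changes: diethylamino in place of pyrrolidin-1-yl gives a 1.2-fold lower number from compound 1 to compound 4 (0.06 log units; within the scatter), which likewise stays within the scatter, while chloro in place of hydrogen on an aromatic carbon gives an at least 2.0-fold lower number from compound 2 to compound 4 (0.31 log units; beyond the scatter), the only one of the three steps beyond the scatter. The reading of compound 2 behind that last step is a limit of the assay and not an exact number: the limit of > 100000 nM in this assay, at which 1 of the 4 values shown sits.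

As far as these compounds go, whether a propyl or a longer chain in the place of the ethyl would separate from ethyl and methyl remains open, as does whether a bromo or a methoxy on the aromatic carbon would match the chloro. The amine end is equally open, since only diethylamino and pyrrolidin-1-yl appear among these compounds, and what a piperidin-1-yl or a dimethylamino would do there is unknown.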